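Replacing the isobutyl group of compound 2 with a nitro group

The compounds below may be only part of what the source reports. "The series", "measured", "known", "first", "only" and "open" are said of these compounds alone.

Of the compounds shown here, two with a shared core have been measured so far. Compound 1 `CN1CCC[C@H]1COc1cncc(C(F)(F)F)c1` carries a trifluoromethyl group on the aromatic ring; in an assay on membranes from brain for displacement of a labelled ligand from Neuronal acetylcholine receptor; alpha4/beta2 (Rattus norvegicus) (a lower number here means a stronger inhibitor, a higher number a weaker inhibitor), compound 1 gives 1.83 nM. For the measured compounds named here, compound 2 `CC(C)Cc1cncc(OC[C@@H]2CCCN2C)c1` carries an isobutyl group in the same place and in this assay compound 2 gives 0.21 nM, the lowest of the two numbers, with compound 1 as its only neighbour. Going by the values given here, the single measured step, an 8.7-fold lower number from compound 1 to compound 2 (0.94 log units; beyond the scatter), shows that the group on this aromatic carbon matters.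

Compound 3 `CN1CCC[C@H]1COc1cncc([N+](=O)[O-])c1` is the next compound: nitro in place of isobutyl on an aromatic carbon. Among the compounds with values here, no measured pair covers this exact exchange, so only the reverse reading of the step from compound 1 to compound 2 bears on it: removing isobutyl in favour of a small group moved the number upward there. By that reasoning compound 3 is expected to sit closer to compound 1 than to compound 2, with an expected step of a 9.5-fold higher number from compound 2 to compound 3 (0.98 log units; beyond the scatter) in this assay. The estimate for compound 3 in this assay is 2 nM, within a range of 0.5 nM to 8 nM.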

Compound 3, inhibition constant: 4.65 nM
Beside the measured number, compound 3's estimate is 2.3-fold (0.37 log units) below it; the measured number falls inside the stated range.
By their numbers in this assay, from the lowest: compound 2; then compound 1; then compound 3.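

The change brings a 22-fold higher number from compound 2 to compound 3 (1.35 log units; beyond the scatter) in this assay, the largest step yet seen at this position, so the low number given by isobutyl does not depend on trifluoromethyl being the comparison group. The position also separates the two groups that stand in place of isobutyl, as nitro for trifluoromethyl gives a 2.5-fold higher number from compound 1 to compound 3 (0.41 log units; beyond the scatter) and so places nitro at the high end of the series; among these three compounds, the only group built of carbon and hydrogen alone gives the lowest number, and none of the three goes against this. No accompanying data speak to what lies behind this order, which therefore remains a description of the numbers alone.

With only three groups in hand, the compounds shown leave open whether a longer chain such as n-hexyl or a ring-bearing group such as cyclohexyl would keep the number as low as isobutyl does, or whether isobutyl is close to a limit. They also leave open where an amine or a carboxylic acid would fall in this order, and whether other carbon-only groups would share the place of isobutyl at its low end.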